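The source may hold more compounds than are shown below. What is called first, only, known or untested is meant among the compounds shown, and "the series" means these compounds.

Of the compounds shown here, three that share one core have so far been measured. In an assay on isolated protein for inhibition of beta-glucuronidase (Bos taurus), read by spectrophotometry, with a stated time of 30 min (on this read-out lower numbers stand for stronger inhibition and higher numbers for weaker inhibition), compound 1 `COc1ccccc1-c1nnc(Nc2ccc(Cl)c(Cl)c2)s1` gives 22600 nM. Compound 2 `COc1ccccc1-c1nnc(Nc2ccc(C)cc2)s1` gives 58100 nM in this assay, and compound 3 `Cc1ccc(-c2nnc(Nc3cccc(Br)c3)s2)c(C)c1` gives 36100 nM. Among these three numbers compound 1 has the lowest; its gap to compound 3 lies within the usual scatter of repeated measurements, so the two cannot be told apart, while its gap to compound 2 lies beyond that scatter. Among the compounds with values here, no pair of these measured compounds differs in only one place, so no single-change step between measured values is available to lean on.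

Compound 4 `Clc1ccc(Nc2nnc(-c3ccccc3)s2)cc1Cl` has not yet been measured in this assay. It differs from compound 1 in one place: hydrogen in place of methoxy on an aromatic carbon. Within the data shown here, nothing among the measured compounds shows what this kind of change does here, so any expectation rests on the general run of the three numbers. Among the measured compounds shown here, with no step to guide it, the change is expected to move the number little, if at all, beyond the scatter, with a slight lean toward a higher number, and the expected step is a 1.3-fold higher number from compound 1 to compound 4 (0.12 log units; within the scatter). Compound 4 is thus estimated at 30000 nM, with a range from 12000 nM to 80000 nM.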

Compound 4, half-maximal inhibitory concentration: 6280 nM
Compound 4: middle estimate off by 4.8-fold (0.68 log units), on the high side; the whole stated range lies above it.
By their numbers in this assay, from the lowest: compound 4; then compounds 1, 3 and 2 (each within the scatter of the next, the first and the last beyond it).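

In this assay, within the data shown here, this is the first single-change step available: hydrogen in place of methoxy on an aromatic carbon, ortho to a large group, gives a 3.6-fold lower number from compound 1 to compound 4 (0.56 log units; beyond the scatter), a modest step that lies beyond the scatter. The earlier compounds shown here could not separate this place from the rest of the structure, but this pair shows that, with everything else in compound 1 held fixed, the methoxy is not needed for inhibition at this place and that the number is lower with hydrogen there. Nothing among the data shown accounts for why the number moves in this direction, so the step stands as an observation from a single pair.

On these data alone, what this place would tolerate beyond these two substituents remains open: a hydroxyl, a fluorine or a methyl there could give a number close to that of compound 4, close to that of compound 1, or outside both. Also open, as far as these compounds go, is whether the same change would give a similar step in compound 2, which carries the methoxy alongside a different substituent pattern on its other aromatic ring.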